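The source may report more compounds than this note shows. Statements on the series, on what has been measured and on what is new or still open speak of the compounds shown alone.

Series of methylthio-triazoles carrying a halogenated phenyl ring, tested in a functional assay on the whole organism for antagonist activity, with Mus musculus as the target; a lower number here means that less compound is needed, a higher number that more compound is needed for the effect. Compound 1 `CSc1nnc(-c2ccc(F)cc2)n1C` gives only a limit in this assay, > 200 mg/kg. Compound 3 `CSc1nnc(-c2ccc(Cl)cc2)n1C` likewise gives only a limit, > 200 mg/kg. Compound 2 `CSc1nnc(-c2ccccc2Cl)n1C` stops at a limit as well, > 50 mg/kg; the difference between the cores of compound 2 and compound 3 is not broken down here.

The measured step that the two limits leave unreadable from compound 3 to compound 1 is fluoro in place of chloro on an aromatic carbon; both ends sit at the limit of > 200 mg/kg in this assay, at which 2 of the 3 values shown sit, so its size is not readable. Compound 4 `CSc1nnc(-c2ccccc2F)n1C` is yet to be measured; its change from compound 2 is fluoro in place of chloro on an aromatic carbon, the same kind of change, though the place differs: ortho to a group of 8 heavy atoms rather than para to a group of 8 heavy atoms.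

With compound 2 at the limit of > 50 mg/kg in this assay, at which 1 of the 3 values shown sits, and no readable step, the step from compound 2 to compound 4 is expected to be a step that the limit leaves unreadable from compound 2 to compound 4. Compound 4 is expected near 150 mg/kg, within 50 mg/kg to 500 mg/kg, most likely again only a limit.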

Compound 4, dose for half-maximal effect: 61.3 mg/kg
Compound 4: the middle estimate sits 2.4-fold (0.39 log units) above what was measured; measured number inside the range.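

The step between compound 2 and compound 4 cannot be read, because compound 2 sits at a limit: the limit of > 50 mg/kg in this assay, at which 1 of the 4 values shown sits.

The compounds shown leave open whether fluoro in place of chloro on an aromatic carbon changes the dose needed at all.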